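The source may hold more compounds than are shown below. What is called first, only, known or untested is meant among the compounds shown, and "the series" means these compounds.

Three compounds built on one shared core were run in a functional assay on UACC-62 cells (Homo sapiens) for inhibition, read by sulforhodamine B assay, with a stated time of 48 h, tested at 10 uM; on this read-out lower numbers stand for less inhibition and higher numbers for more inhibition at the one concentration tested (going by the name of the read-out). Compound 1 `COc1ccc(-c2cn3ccnc3c(-c3ccc4ncn(C5CCCCC5)c4c3)n2)cc1` gives 65.2%. Compound 2 `Fc1ccc(-c2cn3ccnc3c(-c3ccc4ncn(C5CCCCC5)c4c3)n2)cc1` is compound 1 with one change, (fluoro in place of methoxy on an aromatic carbon). In this assay compound 2 gives 31%. That change is a number 34.2 percentage points lower from compound 1 to compound 2 (beyond the scatter). Compound 3 `COc1ccccc1-c1cn2ccnc2c(-c2ccc3ncn(C4CCCCC4)c3c2)n1` keeps the same atoms as compound 1 joined differently, (2-methoxyphenyl in place of 4-methoxyphenyl on an aromatic carbon). In this assay compound 3 gives 25.1%, which is a number 40.1 percentage points lower from compound 1 to compound 3 (beyond the scatter), while the remaining step is a number 5.9 percentage points lower from compound 2 to compound 3 (within the scatter).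

Compound 4 `Fc1ccccc1-c1cn2ccnc2c(-c2ccc3ncn(C4CCCCC4)c3c2)n1` has not yet been measured. It is compound 3 with fluoro in place of methoxy on an aromatic carbon. Among the compounds with values here, this is the same kind of change as the one between compound 1 and compound 2, but the place differs: there the group sits para to a large group, here ortho to a large group. The step from compound 3 is expected to be a number 10.1 percentage points lower from compound 3 to compound 4 (beyond the scatter), smaller than the earlier one, because compound 3 starts from 25.1% and there is little room left to fall. Compound 4 is therefore estimated at 15%, between 2% and 35%.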

Compound 4, a percentage reported as inhibition, at one concentration (the size of the read-out at that concentration, not a potency): 38.2%
Beside the measured number, compound 4's estimate is 23.2 percentage points below it; measured number above the stated range.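

In this assay, fluoro in place of methoxy does not carry over as a fixed effect, since the step from the 2-methoxyphenyl compound is a number 13.1 percentage points higher from compound 3 to compound 4 (beyond the scatter) and its direction is opposite to that of the earlier step, with the gap between them larger than chance would explain: the same change on two cores in this assay, a number 34.2 percentage points lower (beyond the scatter) from compound 1 to compound 2 and a number 13.1 percentage points higher (beyond the scatter) from compound 3 to compound 4, 47.3 percentage points apart, beyond the scatter of two such steps

Among the fluoro compounds, 2-fluorophenyl in place of 4-fluorophenyl is a number 7.2 percentage points higher from compound 2 to compound 4 (within the scatter), so these two cannot be told apart, whereas 2-fluorophenyl in place of 4-methoxyphenyl is a number 27 percentage points lower from compound 1 to compound 4 (beyond the scatter). The two pairs show that the outcome of this change depends on where it is made, but they do not show why, and two pairs at a single concentration give no rule for other places on the ring.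

The compounds shown leave open how other groups would behave in these two places. An amine or a carboxylic acid on the same phenyl ring, for example, could follow either pattern or neither.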